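Swapping Cyclopropyl for (Dimethylcarbamoyl)methyl on the Aromatic Nitrogen

This account rests on a few compounds, and the source may have more. Where it says the series, first, only, none or still open, it means among the compounds named here.

Among the measured compounds shown here, compound 2 `Cc1ccc(C(=O)Nc2cccc(C(F)(F)F)c2)cc1-c1ccc2c(-c3cnn(C4CC4)c3)n[nH]c2c1` gives 3.2 nM in an assay on isolated protein for inhibition of Discoidin domain-containing receptor 2 (Homo sapiens), read by ELISA, with a stated time of 60 min (a lower number here means a stronger inhibitor, a higher number a weaker inhibitor), the lowest of the two numbers so far; its nearest neighbour is compound 1 `Cc1ccc(C(=O)Nc2cccc(C(F)(F)F)c2)cc1-c1ccc2c(-c3cn[nH]c3)n[nH]c2c1` at 55.6 nM. Compound 3 `Cc1ccc(C(=O)Nc2cccc(C(F)(F)F)c2)cc1-c1ccc2c(-c3cnn(CC(=O)N(C)C)c3)n[nH]c2c1` carries (dimethylcarbamoyl)methyl in place of cyclopropyl on an aromatic nitrogen. For the measured compounds named here, the only step bearing on this position is a 17-fold lower number from compound 1 to compound 2 (1.24 log units; beyond the scatter), where a group on that nitrogen in place of hydrogen lowered the number sharply. Compound 3 keeps that nitrogen substituted, though with a different group, so only a modest shift, if any beyond the scatter, is expected: a 1.9-fold higher number from compound 2 to compound 3 (0.27 log units; within the scatter). Compound 3 is therefore estimated at 6 nM, within 1.5 nM to 25 nM.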

Compound 3, half-maximal inhibitory concentration: 2.7 nM
Beside the measured number, compound 3's estimate is 2.2-fold (0.35 log units) above it; the measured number falls inside the stated range.
By their numbers in this assay, from the lowest: compounds 3 and 2 (each within the scatter of the next); then compound 1.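

In this assay, the aromatic nitrogen takes (dimethylcarbamoyl)methyl as readily as cyclopropyl: the two groups read alike, with a 1.2-fold lower number from compound 2 to compound 3 (0.07 log units; within the scatter), although the entering group has no ring and carries a hydrogen-bond acceptor. The gain over hydrogen therefore holds for a second, quite different group, with a 21-fold lower number from compound 1 to compound 3 (1.31 log units; beyond the scatter). Nothing available explains why these two groups read alike. From the compounds shown here alone, whether a methyl, a longer chain, an amine or a carboxylic acid on that nitrogen would read the same stays open. So does whether the carbonyl of the entering group plays any part.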